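Trading 2-Chlorophenyl for 3-Methylphenyl on the Shared Core

The source may hold more compounds than are shown below. What is called first, only, known or untested is meant among the compounds shown, and "the series" means these compounds.

Of the compounds shown here, three built on one shared core have been tested in a functional assay on MGC-803 cells (Homo sapiens) for inhibition, read by MTT assay, with a stated time of 72 h; a lower number here means a stronger inhibitor, a higher number a weaker inhibitor. Compound 3 `C=CC(=O)Nc1cccc(NC(=O)CSc2nc(Nc3ccccc3Cl)c3ccccc3n2)c1` gives 20700 nM in this assay. Its nearest neighbour is compound 1 `O=C(CSc1nc(Nc2ccccc2)c2ccccc2n1)Nc1cccc([N+](=O)[O-])c1`, which in this assay gives 28100 nM; the gap between compound 3 and compound 1 lies within the scatter, so the two sit together. Compound 2 `O=C(CSc1nc(Nc2ccccc2)c2ccccc2n1)Nc1ccc([N+](=O)[O-])cc1` reaches only the limit of this assay, > 50000 nM. Among the compounds with values here, the single measured step, an at least 1.7-fold higher number from compound 1 to compound 2 (0.25 log units; that floor lies within the scatter), touches the amide-type nitrogen end of the core, not the ring-nitrogen end, and its floor rests on (the limit of > 50000 nM in this assay, at which 1 of the 3 values shown sits).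

Compound 4 `C=CC(=O)Nc1cccc(NC(=O)CSc2nc(Nc3cccc(C)c3)c3ccccc3n2)c1` differs from compound 3 by 3-methylphenyl in place of 2-chlorophenyl on a nitrogen on an aromatic ring. No measured step changes that position, so nothing shown speaks for a shift in either direction. The expectation is therefore a step of a 1.0-fold lower number from compound 3 to compound 4 (0.01 log units; within the scatter), no larger than the scatter. Compound 4 is expected to give about 20000 nM in this assay, within a range from 7000 nM to 60000 nM.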

Compound 4, half-maximal inhibitory concentration: 20900 nM
The estimate for compound 4 lay 1.0-fold (0.02 log units) below the measured number; the measured number falls inside the stated range.
By their numbers in this assay, from the lowest: compounds 3, 4 and 1 (each within the scatter of the next). At a limit, above all of these: compound 2.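

Within the data shown here, the swap of 3-methylphenyl in place of 2-chlorophenyl on a nitrogen on an aromatic ring gives a 1.0-fold higher number from compound 3 to compound 4 (0.00 log units; within the scatter) in this assay and supplies the first measured step at this position, which the earlier compounds did not change. For this one pair, the two groups cannot be told apart by their numbers, so this position tolerates the exchange without any shift beyond the scatter. Nothing shown offers a cause for this flat result.

From the compounds shown here alone, both groups are substituted phenyl rings, so it remains open whether phenyl itself on the core of compound 3, an amine or carboxylic acid on that ring, or a longer chain in its place would move the number. Going by these compounds, whether any such change could bring a much lower number also remains unknown.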